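This account rests on a few compounds, and the source may have more. Where it says the series, first, only, none or still open, it means among the compounds named here.

Measured so far:
compound 1, `Cc1ccc2[nH]c(C(=O)N[C@H]3CN(S(=O)(=O)c4cccnc4)C[C@@H]3C(=O)NCCN(C)C)cc2c1`: 90%
compound 2, `Cc1ccc2[nH]c(C(=O)N[C@H]3CN(S(=O)(=O)c4ccnnc4)C[C@@H]3C(=O)NCCN(C)C)cc2c1`: 89%

Both numbers come from a functional assay on HEK293 cells for agonist activity at growth hormone secretagogue receptor type 1 (Homo sapiens), read by HTRF and inositol phosphate accumulation, with a stated time of 90 min, in the presence of a further agent that is not named here; a lower number here means a smaller maximal response, a higher number a larger maximal response. Going by the values given here, on paper compound 2 holds the smaller of the two, but the only measured step, a number 1 percentage points lower from compound 1 to compound 2 (within the scatter), lies within the scatter, so the two compounds cannot be told apart: exchanging one six-membered aromatic ring for another on the sulfonyl sulfur left the maximal response essentially unchanged.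

Compound 3, `Cc1ccc2[nH]c(C(=O)N[C@H]3CN(S(=O)(=O)c4ccnc(C)c4)C[C@@H]3C(=O)NCCN(C)C)cc2c1`, differs from compound 2 in one place: 2-methylpyridin-4-yl in place of pyridazin-4-yl on a sulfonyl sulfur. Among the compounds with values here, the one measured step that bears on this change is a number 1 percentage points lower from compound 1 to compound 2 (within the scatter). That step also altered the ring on the sulfonyl sulfur, and it stayed within the scatter. Since the entering 2-methylpyridin-4-yl group again brings one six-membered aromatic ring to the same position, the expectation in this assay is for no step beyond the scatter, that is, an expected step of a number 1 percentage points lower from compound 2 to compound 3 (within the scatter). Compound 3 is therefore estimated to give 88%, with a range from 75% to 98%.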

Compound 3, largest response reached (Emax), in percent of the reference or control that the assay uses: 91%
The estimate for compound 3 lay 3 percentage points below the measured number, and the stated range covers the measured number.
By their numbers in this assay, from the lowest: compounds 2, 1 and 3 (each within the scatter of the next).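

In this assay, 2-methylpyridin-4-yl on the sulfonyl sulfur, with 7 heavy atoms against 6 and 1 hydrogen-bond acceptor against 2 for pyridazin-4-yl, gives a number 2 percentage points higher from compound 2 to compound 3 (within the scatter) when it replaces pyridazin-4-yl, and a number 1 percentage points higher from compound 1 to compound 3 (within the scatter) when it replaces pyridin-3-yl. Going by these compounds alone, the earlier pair showed only that one unsubstituted ring could stand in for another, whereas these steps show that a ring carrying a methyl group also leaves the three compounds impossible to tell apart by their maximal response, so at this position the extra carbon and the loss of a ring nitrogen relative to pyridazin-4-yl produce no readable change. No supporting measurement is available to explain this flat result.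

The compounds shown leave open whether the maximal response would hold with a phenyl ring, which has no ring nitrogen, or with a saturated group such as cyclohexyl in the same place. They also leave open what a larger or charged substituent on the ring, such as a tert-butyl group or a carboxylic acid, would do to the response.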